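Sulfonylpiperazine series: benzyl and aryl substituents

This account rests on a few compounds, and the source may have more. Where it says the series, first, only, none or still open, it means among the compounds named here.

Compounds measured:
compound 1 `CCCn1c(=O)[nH]c2nc(-c3ccc(S(=O)(=O)N4CCN(Cc5cccc(C)c5)CC4)cc3)[nH]c2c1=O` — 0.397 nM
compound 2 `CCCn1c(=O)[nH]c2nc(-c3ccc(S(=O)(=O)N4CCN(c5cccc(Cl)c5)CC4)cc3)[nH]c2c1=O` — 0.342 nM

In an assay on CHO cells for displacement of a labelled ligand from adenosine receptor A2b (Homo sapiens), read by scintillation counting, with a stated time of 75 min, in the presence of a further agent that is not named here (on this read-out higher numbers stand for weaker inhibition and lower numbers for stronger inhibition), compound 2 gives 0.342 nM, and compound 1 sits beside it at 0.397 nM; the step of a 1.2-fold lower number from compound 1 to compound 2 (0.06 log units; within the scatter) is within the scatter, so the two cannot be ordered.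

Compound 3 `CCCn1c(=O)[nH]c2nc(-c3ccc(S(=O)(=O)N4CCN(Cc5ccc(Br)cc5)CC4)cc3)[nH]c2c1=O` is not yet measured. It differs from compound 2 as follows: 4-bromobenzyl in place of 3-chlorophenyl on an amine nitrogen in a ring. Within the data shown here, the one measured step bears on this, since it also exchanged a benzyl group for an aryl group on the same ring nitrogen and gave a 1.2-fold lower number from compound 1 to compound 2 (0.06 log units; within the scatter), a step within the scatter. No step beyond the scatter is therefore expected in this assay. Compound 3 is estimated at 0.4 nM, range 0.18 nM to 0.9 nM, which would mean an expected step of a 1.2-fold higher number from compound 2 to compound 3 (0.07 log units; within the scatter).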

Compound 3, inhibition constant: 0.153 nM
Estimate against measurement, compound 3: 2.6-fold (0.42 log units) above; the measured number lies below the stated range.
By their numbers in this assay, from the lowest: compound 3; then compounds 2 and 1 (each within the scatter of the next).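

On the amine nitrogen in a ring, the substituent now moves the number in this assay: 4-bromobenzyl in place of 3-chlorophenyl gives a 2.2-fold lower number from compound 2 to compound 3 (0.35 log units; beyond the scatter). A benzyl group alone does not account for this, as compound 1 also carries one, and 4-bromophenyl in place of 3-methylphenyl on the saturated chain carbon gives a 2.6-fold lower number from compound 1 to compound 3 (0.41 log units; beyond the scatter). Nothing measured here explains either step.

The compounds shown do not separate the bromine from its ring position. On these data alone, how a methoxy group or a carboxylic acid on the benzyl ring would read also stays open.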